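A furan ring in place of a nitroethyl ester side group

A few compounds are considered here, and "the series" means these few. Any claim that something is new, unique, unknown or untested is made for them only; others in the source may bear on it.

Compound 1 `COC(=O)C1=C(C)NC(C)=C(C(=O)OCC(C)[N+](=O)[O-])C1c1cccc([N+](=O)[O-])c1` gives 108 nM in a functional assay on HEK293 cells for antagonist activity at Voltage-dependent L-type calcium channel subunit alpha-1C (Oryctolagus cuniculus), read by FLIPR (a lower number here means a stronger inhibitor, a higher number a weaker inhibitor), the higher of the two numbers recorded so far; compound 2 `CCCCCOC(=O)C1=C(C)NC(C)=C(C(=O)OCC)C1c1cccc([N+](=O)[O-])c1` gives 49 nM in this assay. Compound 3 `COC(=O)C1=C(C)NC(C)=C(C(=O)OCc2ccco2)C1c1cccc([N+](=O)[O-])c1` has not yet been measured and differs from compound 1 in one place: furan-2-yl in place of 1-nitroethyl on a saturated chain carbon bound to an oxygen next to a carbonyl group. Among the compounds with values here, no measured pair shows this change, so any expectation rests on compound 1 alone. The author expects a step of a 1.5-fold lower number from compound 1 to compound 3 (0.19 log units; within the scatter) in this assay, lying within or only slightly beyond the scatter, toward a somewhat lower number. For compound 3 the estimated value in this assay is 70 nM, with a range from 25 nM to 220 nM.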

Compound 3, half-maximal inhibitory concentration: 20 nM
For compound 3 the middle estimate is 3.5-fold (0.54 log units) above the measured one, and the stated range ends above it.
By their numbers in this assay, from the lowest: compound 3; then compound 2; then compound 1.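

In this assay, furan-2-yl in place of 1-nitroethyl on a saturated chain carbon bound to an oxygen next to a carbonyl group gives a 5.4-fold lower number from compound 1 to compound 3 (0.73 log units; beyond the scatter). This shows that the ester side group responds to a single change, and that an aromatic ring at this place goes with stronger inhibition than the nitro-bearing chain. No data at hand explain the step.

From the compounds shown here alone, whether a thiophene or phenyl ring on that carbon would match furan-2-yl remains open, as does the effect of an amine there.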